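A change on the amide nitrogen, from sulfamoyl to acetyl

The source may report more compounds than this note shows. Statements on the series, on what has been measured and on what is new or still open speak of the compounds shown alone.

Three compounds sharing a core with a methoxyphenyl ether and an amide have been tested in a functional assay (Homo sapiens) for inhibition, using a membrane potential dye, in the presence of a further agent that is not named here; on this read-out higher numbers stand for weaker inhibition and lower numbers for stronger inhibition. Compound 1 `COc1ccc(NC(=O)c2cc(N)ccc2Oc2ccc(OC)cc2)cc1`, carrying an amino group on the core, gave "no significant activity" (no number reported). Compound 2 `COc1ccc(Oc2ccc([N+](=O)[O-])cc2C(=O)Nc2ccc(Cl)cc2)cc1`, with a nitro group on the core and a 4-chlorophenyl on the amide nitrogen, gives 10100 nM. Compound 3 `COc1ccc(Oc2ccc([N+](=O)[O-])cc2C(=O)Nc2cccc(S(N)(=O)=O)c2)cc1` gives 9900 nM, the lowest of the two numbers, though the step of a 1.0-fold lower number from compound 2 to compound 3 (0.01 log units; within the scatter) lies within the scatter, so the two compounds cannot be told apart.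

Compound 4 `COc1ccc(Oc2ccc([N+](=O)[O-])cc2C(=O)Nc2ccc(C(C)=O)cc2)cc1` is the next step: 4-acetylphenyl in place of 3-sulfamoylphenyl on an amide-type nitrogen. Among the measured compounds shown here, the only measured step at this position, the step from compound 2 to compound 3, changed nothing beyond the scatter, so another exchange of the aryl group on the amide nitrogen is expected to leave this assay largely unchanged. For compound 4 the expected step is a 1.0-fold higher number from compound 3 to compound 4 (0.00 log units; within the scatter). Compound 4 is therefore estimated at 10000 nM, with a range from 3000 nM to 35000 nM.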

Compound 4, half-maximal inhibitory concentration: 8100 nM
Compound 4: the middle estimate sits 1.2-fold (0.09 log units) above what was measured; the measured number falls inside the stated range.
By their numbers in this assay, from the lowest: compounds 4, 3 and 2 (each within the scatter of the next).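

The third group on the amide nitrogen tells the same story as the first two: in this assay, 4-acetylphenyl in place of 3-sulfamoylphenyl gives a 1.2-fold lower number from compound 3 to compound 4 (0.09 log units; within the scatter) and so does not separate the two compounds. Acetyl in place of chloro on an aromatic carbon gives a 1.2-fold lower number from compound 2 to compound 4 (0.10 log units; within the scatter) and likewise moves nothing beyond the scatter, so chloro, sulfamoyl and acetyl cannot be told apart on these three compounds, even though the hydrogen-bond donor count of the group entering compound 4 is 0. No supporting measurement is available to explain this flat result.

From the compounds shown here alone, whether a carboxylic acid or a longer alkyl chain on this aryl ring would shift the number remains open. So does the role of the nitro group on the core, since compound 1 differs from the others in more than one place.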